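Predicting compound 4 from a repeated side-chain change

This account rests on a few compounds, and the source may have more. Where it says the series, first, only, none or still open, it means among the compounds named here.

Compound 1, `COc1ccc(C2=[N+]3C(=Nc4c(-c5ccccc5)c5c(n4[B-]3(F)F)-c3ccc(OCC(=O)N[C@@H](CC(=O)O)C(=O)O)cc3CC5)C(c3ccccc3)=C2I)cc1`: 21 nM
Compound 2, `COc1ccc(C2=[N+]3C(=Nc4c(-c5ccccc5)c5c(n4[B-]3(F)F)-c3ccc(OCC(=O)N[C@@H](CCC(=O)O)C(=O)O)cc3CC5)C(c3ccccc3)=C2I)cc1`: 78 nM
Compound 3, `COc1ccc2c(c1)CCc1c(-c3ccccc3)c3n(c1-2)[B-](F)(F)[N+]1=C(c2ccc(OCC(=O)N[C@@H](CC(=O)O)C(=O)O)cc2)C(I)=C(c2ccccc2)C1=N3`: 55 nM

Of the compounds shown here, three have been measured in a toxicity assay on HeLa cells (Homo sapiens) for cytotoxicity, read by CCK-8 assay, with stated times of 16 h and 24 h; on this read-out lower numbers stand for stronger inhibition and higher numbers for weaker inhibition. Compound 1 gives 21 nM, compound 2 gives 78 nM, and compound 3 gives 55 nM. Compound 2 differs from compound 1 by carboxymethyl in place of carboxy on a saturated chain carbon, two bonds along the chain from an amide-type nitrogen and a carbonyl carbon, and this change produced a 3.7-fold higher number from compound 1 to compound 2 (0.57 log units; beyond the scatter). Compound 3 is built from the same atoms as compound 1, joined differently; the difference between the two cores is not broken down here. The values of compound 3 and compound 2 lie within the scatter of each other.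

Compound 4, `COc1ccc2c(c1)CCc1c(-c3ccccc3)c3n(c1-2)[B-](F)(F)[N+]1=C(c2ccc(OCC(=O)N[C@@H](CCC(=O)O)C(=O)O)cc2)C(I)=C(c2ccccc2)C1=N3`, has not been measured. Going by the values given here, it differs from compound 3 by carboxymethyl in place of carboxy on a saturated chain carbon, two bonds along the chain from an amide-type nitrogen and a carbonyl carbon, which is the same change, at the same place, as the one from compound 1 to compound 2. Because that change gave a 3.7-fold higher number from compound 1 to compound 2 (0.57 log units; beyond the scatter) on the core of compound 1, the same step is expected on the core of compound 3. Compound 4 is therefore estimated to give 180 nM in this assay, a step of a 3.3-fold higher number from compound 3 to compound 4 (0.51 log units; beyond the scatter), with an expected range from 80 nM to 400 nM.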

Compound 4, half-maximal inhibitory concentration: 119 nM
Compound 4: the middle estimate sits 1.5-fold (0.18 log units) above what was measured; the range from low to high includes it.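

In this assay, carboxymethyl in place of carboxy on the core of compound 3 gives a 2.2-fold higher number from compound 3 to compound 4 (0.34 log units; beyond the scatter). Set beside the earlier step, the change moves the number the same way on both cores, and the two sizes cannot be told apart: the same change on two cores in this assay, a 3.7-fold higher number (0.57 log units; beyond the scatter) from compound 1 to compound 2 and a 2.2-fold higher number (0.34 log units; beyond the scatter) from compound 3 to compound 4, 1.7-fold (0.23 log units) apart, within the scatter of two such steps. This shows that, for these two pairs, the change carried from one core to the other in direction and, within the scatter, in size, but two pairs do not establish a rule for the series, and they do not show why the number rises or whether the change would behave alike on any further core.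

The compounds shown leave open whether a longer chain than the 1,3-dicarboxypropyl one would raise the number further, and whether an amine or a primary amide in place of the carboxy group would fit the same trend. They also leave open whether the step holds in cells other than the HeLa line.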